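The source may report more compounds than this note shows. Statements on the series, on what has been measured and on what is new or still open speak of the compounds shown alone.

Compound 1, `CCCSc1nc(N/N=C(\C)c2ccccc2O)c2nnn(Cc3ccccc3Cl)c2n1`: in a functional assay on MCF7 cells (Homo sapiens) for antiproliferative activity, read by MTT assay, with a stated time of 72 h (on this read-out lower numbers stand for stronger inhibition and higher numbers for weaker inhibition), compound 1 gives > 64000 nM, a limit of the assay and not a number.
Compound 2, `CCCSc1nc(N/N=C/c2cc(OC)c(OC)c(OC)c2)c2nnn(Cc3ccccc3)c2n1`: in this assay compound 2 gives > 64000 nM, again a limit.
Compound 3, `CCCSc1nc(N/N=C(\C)c2ccccc2O)c2nnn(Cc3ccc(F)cc3)c2n1`: in this assay compound 3 gives > 64000 nM, also a limit.

Where compound 3 stands is therefore known only as a limit, and the two further values shown are limits as well. All three sit at the limit of > 64000 nM in this assay, at which 3 of the 3 values shown sit. Among the measured compounds shown here, the single measured step that touches compound 3, a step that the two limits leave unreadable from compound 1 to compound 3, is unreadable; both of its ends are limits, so no size can be taken from it.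

Compound 4, `CCCSc1nc(N/N=C(\C)c2ccccc2O)c2nnn(Cc3ccc(Br)cc3)c2n1`, differs from compound 3 by bromo in place of fluoro on an aromatic carbon of a six-membered aromatic ring of carbon only, para to a large group. For the measured compounds named here, no measured step with a readable size bears on this change; the only neighbouring step is the unreadable one just described.

With every value shown resting at the limit of > 64000 nM in this assay, at which 3 of the 3 values shown sit, the expectation for compound 4 is a step that the limit leaves unreadable from compound 3 to compound 4 that stays within the scatter, with the read-out most probably returning once more as a limit rather than a number. Compound 4 is accordingly estimated at 100000 nM in this assay, with a range from 40000 nM to 300000 nM.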

Compound 4, half-maximal inhibitory concentration: 15600 nM
Compound 4: the middle estimate sits 6.4-fold (0.81 log units) above what was measured; the measured number lies below the stated range.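

In this assay compound 4 gives a real number (15600 nM). Compound 4 is the only compound shown that has left the limit of the assay: the limit of > 64000 nM in this assay, at which 3 of the 4 values shown sit.

Among the compounds shown here, the change of fluoro to bromo on an aromatic carbon, para to a large group, gives an at least 4.1-fold lower number from compound 3 to compound 4 (0.61 log units; beyond the scatter), so this position on the benzyl group can shift the read-out, which the earlier compounds could not show. The wider exchange of 2-chlorophenyl for 4-bromophenyl gives an at least 4.1-fold lower number from compound 1 to compound 4 (0.61 log units; beyond the scatter), whereas the step that has a limit at both ends cannot be read.

Going by these compounds, each readable step starts from a limit, so its full size stays open, and so does whether the shift is specific to bromo or would also appear with chloro, iodo, methyl or methoxy on the same aromatic carbon. On these data alone, it is also open whether 4-bromobenzyl would have a similar effect on a core carrying the 3,4,5-trimethoxyphenyl hydrazone of compound 2, or with a chain other than the propylthio group.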